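Side-chain change on compound 2: working notes

This account rests on a few compounds, and the source may have more. Where it says the series, first, only, none or still open, it means among the compounds named here.

Values in a functional assay on HepG2 cells (Homo sapiens) for cytotoxicity, read by MTT assay, with a stated time of 72 h; on this read-out higher numbers stand for weaker inhibition and lower numbers for stronger inhibition:
- compound 1 `CCN1CCN(CCC(=O)Nc2ccc3[nH]c(-c4ccc(Br)cc4)nc3c2)CC1`: 27400 nM
- compound 2 `CCN1CCN(CCC(=O)Nc2ccc3[nH]c(-c4ccc(C)cc4)nc3c2)CC1`: 14600 nM
- compound 3 `CCN1CCN(CCC(=O)Nc2ccc3[nH]c(-c4cccn4C)nc3c2)CC1`: > 50000 nM (a limit)

Compound 2 and compound 1 are the two compounds with actual numbers, and they lie close together: a 1.9-fold lower number from compound 1 to compound 2 (0.27 log units; within the scatter). The step to the limit is an at least 3.4-fold higher number from compound 2 to compound 3 (0.53 log units; beyond the scatter).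

Compound 4 `Cc1ccc(-c2nc3cc(NC(=O)CN4CCCC4)ccc3[nH]2)cc1` keeps the 4-methylphenyl group of compound 2 and changes the side chain: pyrrolidin-1-yl in place of (4-ethylpiperazin-1-yl)methyl on a saturated chain carbon bound to a carbonyl carbon. The measured steps bear on it only indirectly, since each one changes the aromatic substituent and none changes this chain. No step beyond the scatter is therefore expected in this assay, and no direction is favoured, though the uncertainty is wide.

The expected size is a 1.2-fold higher number from compound 2 to compound 4 (0.09 log units; within the scatter).

For compound 4 the estimate is 18000 nM, with an expected range of 6000 nM to 50000 nM.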

Compound 4, half-maximal inhibitory concentration: > 50000 nM
Compound 4 was reported as a limit; the forecaster's own chance of this, stated with the estimate: 20%; middle value at least 2.7-fold (0.44 log units) away from the limit.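

In this assay, within the data shown here, the side chain, which the earlier steps left unchanged, proves able to shift the read-out beyond the scatter: an at least 3.4-fold higher number from compound 2 to compound 4 (0.53 log units; beyond the scatter). Compound 4 keeps the 4-methylphenyl group of compound 2, so this step belongs to pyrrolidin-1-yl in place of (4-ethylpiperazin-1-yl)methyl alone. The value of compound 4 is a limit, so only a floor on the step can be read: the limit of > 50000 nM in this assay, at which 2 of the 4 values shown sit.

Open, as far as these compounds go, is whether the ring or the methyl link carries the step. A 4-ethylpiperazin-1-yl or a pyrrolidin-1-ylmethyl group on the same saturated chain carbon would separate the two.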